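Adding an Isopropyl to a Peptidic Sulfonamide Inhibitor

This account rests on a few compounds, and the source may have more. Where it says the series, first, only, none or still open, it means among the compounds named here.

Compound 1 `CSCC[C@H](NC(=O)[C@H](C)NC(=O)[C@H](C)NC(=O)CC[C@H](NS(=O)(=O)c1ccc(Cl)c(C(F)(F)F)c1)C(=O)O)C(N)=O` is tested in an assay on isolated protein for inhibition of Matrilysin (Homo sapiens), read by fluorescence, with a stated time of 15 min (a lower number here means a stronger inhibitor, a higher number a weaker inhibitor), where compound 1 gives 6700 nM. Compound 3 `O=C(O)[C@H](CCc1ccccc1)NS(=O)(=O)c1ccc(Cl)c(C(F)(F)F)c1` gives 6100 nM in this assay, a number within the scatter of that of compound 1. Compound 2 `CC(C)C[C@H](NC(=O)CNC(=O)CC[C@H](NS(=O)(=O)c1ccc(Cl)c(C(F)(F)F)c1)C(=O)O)C(=O)N[C@H](C(N)=O)C(C)C` gives 56 nM, far below compound 1 and beyond the scatter. Compound 4 `CSCC[C@H](NC(=O)[C@H](CC(C)C)NC(=O)[C@H](C)NC(=O)CC[C@H](NS(=O)(=O)c1ccc(Cl)c(C(F)(F)F)c1)C(=O)O)C(N)=O` differs from compound 1 by isopropyl in place of hydrogen on a saturated chain carbon, two bonds along the chain from an amide-type nitrogen and a carbonyl carbon. For the measured compounds named here, no measured pair shows this exact change, so its size is uncertain. Because compound 2 reaches 56 nM on the same core, a larger branched side chain appears compatible with much stronger inhibition. The step of a 4.5-fold lower number from compound 1 to compound 4 (0.65 log units; beyond the scatter) is therefore expected to lower the number beyond the scatter. Compound 4 is estimated at 1500 nM, with a range from 400 nM to 5000 nM.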

Compound 4, half-maximal inhibitory concentration: 440 nM
Compound 4: the middle estimate sits 3.4-fold (0.53 log units) above what was measured, within the range that was stated.
By their numbers in this assay, from the lowest: compound 2; then compound 4; then compounds 3 and 1 (each within the scatter of the next).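

For the compounds shown here, the pair gives the first direct reading at this position: on a saturated chain carbon, two bonds along the chain from an amide-type nitrogen and a carbonyl carbon, the change from methyl to isobutyl brings a 15-fold lower number from compound 1 to compound 4 (1.18 log units; beyond the scatter) in this assay. The position is therefore not indifferent to its side chain, and it accepts isobutyl with a gain. No measurement available here accounts for that gain. Going by these compounds alone, with only this one pair at the position, it remains open whether the gain depends on branching, and how a straight butyl chain, a phenyl ring or an amine would compare there.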